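Swapping chlorines for fluorines on the aryl ketone of compound 1

The source may report more compounds than this note shows. Statements on the series, on what has been measured and on what is new or still open speak of the compounds shown alone.

Measured compounds:
- Compound 1, `COc1cc(-c2cc(/C=C/C(=O)c3ccc(Cl)c(Cl)c3)[nH]n2)cc(OC)c1OC`: 97%
- Compound 2, `COc1ccc(-c2cc(/C=C/C(=O)c3ccc(N)cc3)[nH]n2)cc1`: 90%
- Compound 3, `COc1cc(C(=O)/C=C/c2cc(-c3cc(OC)c(OC)c(OC)c3)n[nH]2)cc(OC)c1OC`: 95%

In a functional assay on SK-MEL-5 cells (Homo sapiens) for cytotoxicity, read by sulforhodamine B assay, with a stated time of 48 h, tested at 0.1 uM (a lower number here means a stronger effect, a higher number a weaker effect of the compound at the concentration tested), compound 1 gives 97%. This is the highest of the three numbers, yet compound 3, with 95%, and compound 2, with 90%, both sit within the scatter of compound 1, so the three compounds show essentially the same weak effect at this concentration. No single-point steps between measured compounds are shown, so the numbers themselves are all that can be read.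

Compound 4, `COc1cc(-c2cc(/C=C/C(=O)c3ccc(F)c(F)c3)[nH]n2)cc(OC)c1OC`, has not been measured. It differs from compound 1 in one place: 3,4-difluorophenyl in place of 3,4-dichlorophenyl on a carbonyl carbon. The carbonyl carbon, the double-bonded chain carbon and the shared core are unchanged.

Given that all three measured compounds cluster near the top of the scale, the step from compound 1 to compound 4 in this assay is expected to be small, with no direction beyond the scatter, a number 2 percentage points lower from compound 1 to compound 4 (within the scatter). Compound 4 is estimated at 95%, within 82% to 105%.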

Compound 4, a percentage reported as activity, at one concentration (the size of the read-out at that concentration, not a potency): 96%
For compound 4 the middle estimate is 1 percentage points below the measured one; the range from low to high includes it.
By their numbers in this assay, from the lowest: compounds 2, 3, 4 and 1 (each within the scatter of the next).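

Among these compounds, this is the first comparison in the set between two compounds that differ in only one place. In this assay, putting 3,4-difluorophenyl in place of 3,4-dichlorophenyl on a carbonyl carbon gives a step of a number 1 percentage points lower from compound 1 to compound 4 (within the scatter), so at this single concentration the two halogen pairs cannot be told apart at this position. No measurement shown here explains the closeness of the two numbers.

The compounds shown leave open whether a group of another kind on this carbonyl carbon, such as a carboxylic acid or a nitrile, would move the read-out beyond the scatter. They also leave open whether the chlorine and fluorine pairs would separate at a higher concentration, where a stronger effect might be seen.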